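Nitroimidazole ethylsulfonamides: exchanging the sulfonamide substituent

This account rests on a few compounds, and the source may have more. Where it says the series, first, only, none or still open, it means among the compounds named here.

Three compounds of the series have been run in a functional assay on HCT-116 cells (Homo sapiens) for cytotoxicity, read by sulforhodamine B assay, with stated times of 4 h and 5 days; on this read-out higher numbers stand for weaker inhibition and lower numbers for stronger inhibition. Compound 1 `COCCCNS(=O)(=O)CCn1c([N+](=O)[O-])cnc1C` gives 3700000 nM. Compound 2 `Cc1ncc([N+](=O)[O-])n1CCS(=O)(=O)NCCN(C)C` gives 800000 nM, and compound 3 `CCN(CC)CCNS(=O)(=O)CCn1c([N+](=O)[O-])cnc1C` gives 1300000 nM. Compound 2 shows the lowest number of the three, but a 1.6-fold higher number from compound 2 to compound 3 (0.21 log units; within the scatter) keeps it and compound 3 within the scatter of each other, so no order between them is claimed; only a 4.6-fold lower number from compound 1 to compound 2 (0.67 log units; beyond the scatter) sets compound 2 apart from compound 1.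

Compound 4 `Cc1ncc([N+](=O)[O-])n1CCS(=O)(=O)N1CCOCC1` is not yet measured. It differs from compound 2 by morpholin-4-yl in place of (2-(dimethylamino)ethyl)amino on a sulfonyl sulfur. For the measured compounds named here, the steps that bear on it are a 4.6-fold lower number from compound 1 to compound 2 (0.67 log units; beyond the scatter) and a 2.8-fold lower number from compound 1 to compound 3 (0.45 log units; beyond the scatter), both modest moves to lower numbers on adding an amino-bearing chain; the change to compound 4 takes that chain away and brings in a ring carrying one oxygen, which points roughly the other way. A modest rise is therefore expected, a 3.1-fold higher number from compound 2 to compound 4 (0.49 log units; beyond the scatter), with compound 4 estimated at 2500000 nM, range 800000 nM to 7000000 nM.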

Compound 4, half-maximal inhibitory concentration: 38000 nM
Beside the measured number, compound 4's estimate is 66-fold (1.82 log units) above it; the measured number lies below the stated range.
By their numbers in this assay, from the lowest: compound 4; then compounds 2 and 3 (each within the scatter of the next); then compound 1.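

At the sulfonyl sulfur, morpholin-4-yl in place of (2-(dimethylamino)ethyl)amino gives a 21-fold lower number from compound 2 to compound 4 (1.32 log units; beyond the scatter) in this assay, and in place of (3-methoxypropyl)amino it gives a 97-fold lower number from compound 1 to compound 4 (1.99 log units; beyond the scatter) on the same read-out. These steps are larger than any among compounds 1, 2 and 3, so this position tolerates far more movement than the open-chain substituents alone showed, and an amino-bearing chain is not needed for a low number here. No measurement shown accounts for the size of these steps.

The change to compound 4 replaces an open chain carrying a hydrogen-bond donor with a ring lacking one and also brings in a ring oxygen, so these features remain unseparated. Piperidin-1-yl or dimethylamino on the sulfonyl sulfur would help to tell them apart.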